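One Methyl Removed: From Compound 2 to Compound 4

The source may hold more compounds than are shown below. What is called first, only, known or untested is meant among the compounds shown, and "the series" means these compounds.

Of the compounds shown here, three have been measured in a functional assay on cells (Mus musculus) for cytotoxicity, read by MTT assay, with a stated time of 72 h; a higher number here means a weaker inhibitor, a lower number a stronger inhibitor. Compound 1 `COc1cc2cc(Cc3ccc(O)cc3)c(=O)oc2cc1O` gives 61800 nM. Compound 2 `COc1ccc(CCC(=O)c2ccc(O)cc2)c(OC)c1` gives 32200 nM. Compound 3 `Oc1ccc(C[C@H]2COc3cc(O)ccc3C2)cc1` gives 44500 nM. Compound 2 sits at the low end of these three numbers, yet its gaps to compound 3 and to compound 1 both lie within the scatter of repeated measurements, so none of the three can be set apart from the others on the evidence so far.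

Compound 4 `COc1ccc(CCC(=O)c2ccc(O)cc2)c(O)c1` has not been measured in this assay. It differs from compound 2 in a single place: hydrogen in place of methyl on an oxygen on an aromatic ring. For the measured compounds named here, no pair of measured compounds shows this same change, so there is no measured step on which to lean. With the three measured numbers so close together and nothing to show that removing one methyl from an oxygen on an aromatic ring moves the number, the account expects a step from compound 2 to compound 4 of about a 1.1-fold lower number from compound 2 to compound 4 (0.03 log units; within the scatter), that is, nothing beyond the scatter in either direction. Compound 4 is therefore expected to give roughly 30000 nM in this assay, within a range from 12000 nM to 75000 nM.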

Compound 4, half-maximal inhibitory concentration: 81400 nM
The estimate for compound 4 lay 2.7-fold (0.43 log units) below the measured number, outside the stated range (above it).
By their numbers in this assay, from the lowest: compounds 2, 3, 1 and 4 (each within the scatter of the next, the first and the last beyond it).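

In this assay, for the compounds shown here, going from methoxy to hydroxy on this oxygen gives a 2.5-fold higher number from compound 2 to compound 4 (0.40 log units; beyond the scatter) and supplies the first step between two compounds that differ in one place. Unlike the gaps from compound 2 to compound 3 and to compound 1, which stay within the scatter, this modest step lies beyond it, so the methyl on this oxygen on an aromatic ring is not a silent feature of compound 2: with hydrogen in its place, the number rises, which here means a weaker inhibitor. This single pair gives the size and direction of the step, but nothing measured here accounts for why the number moves.

On these data alone, whether removing the methyl from the methoxy that compound 4 keeps would produce a step of similar size remains open, as does whether the change would read the same on another core. As far as these compounds go, it is also open how an ethoxy group, with its longer chain on this oxygen, or an amine on the aromatic ring at this place would read in this assay.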